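This account rests on a few compounds, and the source may have more. Where it says the series, first, only, none or still open, it means among the compounds named here.

Measured compounds in a functional assay on U-87MG ATCC cells (Homo sapiens) for antiproliferative activity, read by MTT assay, with a stated time of 48 h; a lower number here means a stronger inhibitor, a higher number a weaker inhibitor:

Compound 1, `COc1ncc(-c2ccc3nc(N)nn3c2)cc1NS(=O)(=O)c1ccc(F)cc1`, gives 3950 nM.
Compound 2, `COc1ncc(-c2ccc3nc(N)nn3c2)cc1NS(=O)(=O)c1ccc(C)cc1`, gives 2510 nM.
Compound 3, `COc1ncc(-c2ccn3nc(NC(C)=O)nc3c2)cc1NS(=O)(=O)c1ccc(C)cc1`, gives 2030 nM.

Compound 1 and compound 2 share one core and differ in a single spot: fluoro in place of methyl on an aromatic carbon. That exchange gives a 1.6-fold higher number from compound 2 to compound 1 (0.20 log units; within the scatter), so this assay does not tell the two apart. Compound 3 is built on a different core; the difference between the two cores is not broken down here. Its number in this assay and that of compound 2 lie within the usual scatter of each other, as do its number and that of compound 1, so none of the three stands out from the others.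

Compound 4, `COc1ncc(-c2ccn3nc(NC(C)=O)nc3c2)cc1NS(=O)(=O)c1ccc(F)cc1`, has not yet been measured. It comes from compound 3 by the same change that turns compound 2 into compound 1: fluoro in place of methyl on an aromatic carbon. The place of the change is described in the same words for both pairs, so it is the same change, carried over to the other core. Within the data shown here, the only guide to its size is the step already seen on the first core. Compound 4 is therefore expected to show a 1.6-fold higher number from compound 3 to compound 4 (0.20 log units; within the scatter) in this assay, because this mirrors a 1.6-fold higher number from compound 2 to compound 1 (0.20 log units; within the scatter). On that basis compound 4 is estimated at 3200 nM, with a range from 1600 nM to 6500 nM. A number within the usual scatter of compound 3 would be no surprise.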

Compound 4, half-maximal inhibitory concentration: 2410 nM
The estimate for compound 4 lay 1.3-fold (0.12 log units) above the measured number, within the range that was stated.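

Exchanging 4-methylphenyl for 4-fluorophenyl on the second core gives a 1.2-fold higher number from compound 3 to compound 4 (0.07 log units; within the scatter) in this assay, so this assay does not tell these two compounds apart. Set beside the earlier step, the same change gives the same reading on both cores, as far as this assay can show: the same change on two cores in this assay, a 1.6-fold higher number (0.20 log units; within the scatter) from compound 2 to compound 1 and a 1.2-fold higher number (0.07 log units; within the scatter) from compound 3 to compound 4, 1.3-fold (0.12 log units) apart, within the scatter of two such steps

Among these compounds, neither step can be told from the differences seen between repeated measurements, so the agreement means only that this exchange has no readable effect on either of these two cores; it does not show that a step of clear size would carry from one core to the other, and it says nothing about any further core.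

The compounds shown leave open what other groups would do on this aromatic ring, para to a large group, in place of methyl or fluoro, for example an amine, a carboxylic acid or a longer chain. Also open is what the core itself contributes to the numbers, as each single-change pair shown keeps its core fixed and the two cores are never compared one change at a time.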